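The compounds below may be only part of what the source reports. "The series", "measured", "known", "first", "only" and "open" are said of these compounds alone.

Two members of the series have been measured in a functional assay on HT-29 cells (Homo sapiens) for cytotoxicity, read by MTT assay, with a stated time of 72 h; on this read-out lower numbers stand for stronger inhibition and higher numbers for weaker inhibition. Compound 1, `CN(C)CCCNc1nc(-c2ccc(NC(=O)Nc3ccccc3F)cc2)nc2ccsc12`, gives 470 nM. Compound 2, `CCN(CC)CCCNc1nc(-c2ccc(NC(=O)Nc3ccccc3)cc2)nc2ccsc12`, gives 730 nM, the higher of the two numbers; its gap to compound 1 lies within the scatter, so the two values read as alike. Compound 3, `CCN(CC)CCCNc1nc(-c2ccc(NC(=O)Nc3ccccc3F)cc2)nc2ccsc12`, has not yet been measured. It differs from compound 2 in one place: fluoro in place of hydrogen on an aromatic carbon. For the measured compounds named here, compound 1 also carries this fluoro but differs from compound 3 elsewhere, so no step across this single change has been measured. The closeness of compound 1 and compound 2 gives no sign of a large shift from this change. Compound 3 is therefore expected to show only a small step, a 1.3-fold lower number from compound 2 to compound 3 (0.12 log units; within the scatter), not beyond the scatter. The estimate for compound 3 is 560 nM, with an expected range from 250 nM to 1250 nM.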

Compound 3, half-maximal inhibitory concentration: 550 nM
For compound 3 the middle estimate is 1.0-fold (0.01 log units) above the measured one; measured number inside the range.
By their numbers in this assay, from the lowest: compounds 1, 3 and 2 (each within the scatter of the next).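

In this assay, fluoro in place of hydrogen on an aromatic carbon, ortho to a large group, now has a directly measured step (a 1.3-fold lower number from compound 2 to compound 3 (0.12 log units; within the scatter)), and phenylcarbamoyl to (2-fluorophenyl)carbamoyl stays within the scatter. With the (2-fluorophenyl)carbamoyl group held constant, diethylamino in place of dimethylamino also has its own step (a 1.2-fold higher number from compound 1 to compound 3 (0.07 log units; within the scatter)), which likewise stays within the scatter. No measurement at hand bears on the reason for either result.

The compounds shown leave open whether chloro, methoxy or trifluoromethyl on this same aromatic carbon would give a step beyond the scatter. They also leave open whether a cyclic amine such as morpholine or piperidine in place of diethylamino would do so.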